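This account rests on a few compounds, and the source may have more. Where it says the series, first, only, none or still open, it means among the compounds named here.

Compound 1 `NC(=O)c1nn(C2O[C@H](CO)[C@@H](O)[C@H]2O)cc1[N+](=O)[O-]` gives > 1730 uM in a functional assay on Vero cells (Chlorocebus sabaeus) (a higher number here means a weaker inhibitor, a lower number a stronger inhibitor), which is a limit of the assay and not a number.
Compound 2 `Cc1c([N+](=O)[O-])c(C(N)=O)nn1C1O[C@H](CO)[C@@H](O)[C@H]1O` gives > 1650 uM in this assay, likewise only a limit.
Compound 3 `NC(=O)c1nn([C@@H]2O[C@H](CO)[C@@H](O)[C@H]2O)cc1I` gives > 1350 uM in this assay, again a limit.

Compound 2 therefore stands at a limit, and both other values shown are limits as well. Among the compounds with values here, the single step between measured compounds, a step that the two limits leave unreadable from compound 1 to compound 2, cannot be read: both of its ends sit at limits the limit of > 1650 uM in this assay, at which 1 of the 3 values shown sits (the limit of > 1730 uM in this assay, at which 1 of the 3 values shown sits). Compound 4 `Cc1c(N)c(C(N)=O)nn1C1O[C@H](CO)[C@@H](O)[C@H]1O` differs from compound 2 by amino in place of nitro on an aromatic carbon. Within the data shown here, no measured step bears on this change, so no direction beyond the scatter can be foreseen. The expected step of a number no higher from compound 2 to compound 4 (the limit leaves the size open) rests on no measured footing. Compound 4 is estimated to give 1650 uM in this assay, with a range from 200 uM to 5000 uM, and most probably as a limit once more.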

Compound 4, concentration for 50% inhibition: > 1840 uM
Compound 4: no number, only a limit; the forecaster's own chance of this, stated with the estimate: 80%; at least 1.1-fold (0.04 log units) between middle value and limit.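

In this assay compound 4 gives > 1840 uM, again only a limit. With compound 2 and compound 4 both at limits, the step between them cannot be read. The compounds shown leave open whether any of these changes alters inhibition, and at what concentration inhibition would appear.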